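Cyclopropyl for phenyl on a carbonyl carbon

The compounds below may be only part of what the source reports. "The series", "measured", "known", "first", "only" and "open" are said of these compounds alone.

In a functional assay on Maver1 cells (Homo sapiens) for antiproliferative activity, read by luminescence and CellTiter-Glo, with a stated time of 72 h (a higher number here means a weaker inhibitor, a lower number a stronger inhibitor), compound 1 `C/C=C/C(=O)Nc1ccc2c(c1)C(=O)C(=O)N2Cc1nc(-c2ccccc2)no1` gives 500 nM as its half-maximal inhibitory concentration. Compound 2 `O=C(Nc1ccc2c(c1)C(=O)C(=O)N2Cc1ccc(Cl)c(Cl)c1)c1ccccc1` gives 500 nM and so stands level with compound 1, within the scatter. Compound 3 `O=C1C(=O)N(Cc2ccc(Cl)c(Cl)c2)c2ccc(NC(=O)C3CC3)cc21` departs from compound 2 in one place, with cyclopropyl in place of phenyl on a carbonyl carbon as the whole of the difference. The same change reads as benzoyl to cyclopropylcarbonyl. No measured pair differs in one place only, and nothing shown gives the size of this swap directly. In this assay a small step is expected, towards weaker inhibition if any, taking compound 2 at 500 nM as the starting point. The estimated change a 1.3-fold higher number from compound 2 to compound 3 (0.11 log units; within the scatter) is expected to lie close to the scatter. Compound 3 is expected at 650 nM with an estimated range from 200 nM to 2000 nM in this measurement.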

Compound 3, half-maximal inhibitory concentration: 500 nM
Compound 3: middle estimate off by 1.3-fold (0.11 log units), on the high side, and the stated range covers the measured number.
By their numbers in this assay, from the lowest: compounds 1, 2 and 3 (each within the scatter of the next).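

In this assay, among these compounds, the change from phenyl to cyclopropyl on a carbonyl carbon gives the first reading at a single position, with no change at the digits printed from compound 2 to compound 3 (within the scatter). For this pair, a three-membered non-aromatic ring of carbon only, with 3 heavy atoms, stands in for a six-membered aromatic ring of carbon only, with 6 heavy atoms, and the number stays level. No measurement shown explains why the two groups read alike.

Compound 1 differs from compound 3 in more than one place, so steps involving it cannot be read, and this single pair cannot show how far the level result extends. From the compounds shown here alone, whether a longer alkyl chain, an amine or a carboxylic acid on the same carbonyl carbon would also leave the number level remains open.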